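This account rests on a few compounds, and the source may have more. Where it says the series, first, only, none or still open, it means among the compounds named here.

Compounds measured so far: compound 1 `COc1cccc(N2C(=O)CS/C2=N\c2csc(-c3ccc(C)cc3)c2)c1` and compound 2 `COc1cccc(N2C(=O)CS/C2=N\c2csc(-c3ccc(Cl)cc3)c2)c1`.

In a functional assay on HT-29 cells (Homo sapiens) for cytotoxicity, read by MTT assay, with a stated time of 72 h (on this read-out lower numbers stand for stronger inhibition and higher numbers for weaker inhibition), compound 1 gives > 50000 nM, which is a limit of the assay and not a number. In this assay, among the compounds with values here, compound 2 gives 24600 nM, the only number among the two values shown. Within the data shown here, the single measured step, an at least 2.0-fold lower number from compound 1 to compound 2 (0.30 log units; that floor lies within the scatter), is a chloro in place of a methyl on an aromatic carbon, and its size rests on the fact that (the limit of > 50000 nM in this assay, at which 1 of the 2 values shown sits). Compound 3 `CN(C)c1ccc(N2C(=O)CS/C2=N\c2csc(-c3ccc(Cl)cc3)c2)cc1` differs from compound 2 at another place: 4-(dimethylamino)phenyl in place of 3-methoxyphenyl on an amide-type nitrogen in a ring, on an amide-type nitrogen in a ring. No measured step touches this aryl group, so nothing shown bears directly on the change, and the number for compound 3 is expected to lie near that of compound 2 with wide uncertainty. Compound 3 is therefore estimated at 20000 nM, in the range from 5000 nM to 80000 nM. That estimate means a step of a 1.2-fold lower number from compound 2 to compound 3 (0.09 log units; within the scatter), expected to be within the scatter, in no set direction.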

Compound 3, half-maximal inhibitory concentration: 29200 nM
Estimate against measurement, compound 3: 1.5-fold (0.16 log units) below; the measured number falls inside the stated range.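

In this assay, within the data shown here, the exchange at the amide-type nitrogen gives the first reading for this position, since the earlier compounds all carry 3-methoxyphenyl there: a 1.2-fold higher number from compound 2 to compound 3 (0.07 log units; within the scatter). The position therefore accepts 4-(dimethylamino)phenyl in place of 3-methoxyphenyl with the 4-chlorophenyl-bearing remainder of the core kept the same, and the two values cannot be told apart, although the exchange replaces the substituent and its printed ring position together, so this one step cannot separate those two differences. Nothing measured here offers a reason for this result.

On these data alone, it stays open whether a carboxylic acid on the phenyl ring, a plain unsubstituted phenyl, or an ethyl chain in place of the whole aryl group would give a number beyond the scatter from those of compound 2 and compound 3. As far as these compounds go, it also stays open whether the methyl and chloro groups on the other aryl ring would compare in the same way with 4-(dimethylamino)phenyl on the amide-type nitrogen.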